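Cyclopropylmethyl for isopropyl on the carbonyl-bound oxygen

The source may report more compounds than this note shows. Statements on the series, on what has been measured and on what is new or still open speak of the compounds shown alone.

Three compounds of the shared core have numbers in a functional assay on L1210 cells (Mus musculus) for inhibition; a higher number here means a weaker inhibitor, a lower number a stronger inhibitor. Compound 2 `COC(=O)Nc1nc2cc(C(=O)OC(C)C)ccc2[nH]1` gives 700 nM. Compound 1 `CC(C)OC(=O)Nc1nc2cc(C(=O)OC(C)C)ccc2[nH]1` gives 730 nM, and compound 3 `CCOC(=O)Nc1nc2cc(C(=O)OCC)ccc2[nH]1` gives 760 nM. Compound 2 holds the lowest of the three numbers, but its distance to compound 1 and to compound 3 lies within the scatter, so the three stand level. Among the measured compounds shown here, the only single-point step, a 1.0-fold lower number from compound 1 to compound 2 (0.02 log units; within the scatter), exchanges groups on an oxygen next to a carbonyl group and moves nothing beyond the scatter. Compound 3 differs from compound 2 in two places, and its value and that of compound 2 show no gap beyond the scatter either.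

Compound 4 `COC(=O)Nc1nc2cc(C(=O)OCC3CC3)ccc2[nH]1` carries the change (cyclopropylmethyl in place of isopropyl on an oxygen next to a carbonyl group). For the measured compounds named here, no measured step alters exactly this group on its own; the level values of compounds 1, 2 and 3 across varied groups on an oxygen next to a carbonyl group are the only guide. Because a 1.0-fold lower number from compound 1 to compound 2 (0.02 log units; within the scatter) stayed within the scatter, compound 4 is expected to show no change at the digits printed from compound 2 to compound 4 (within the scatter) in this assay, with no direction beyond the scatter. The estimate for compound 4 is 700 nM, range 350 nM to 1400 nM.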

Compound 4, half-maximal inhibitory concentration: 6900 nM
Beside the measured number, compound 4's estimate is 9.9-fold (0.99 log units) below it; measured number above the stated range.
By their numbers in this assay, from the lowest: compounds 2, 1 and 3 (each within the scatter of the next); then compound 4.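

With a 9.9-fold higher number from compound 2 to compound 4 (0.99 log units; beyond the scatter) in this assay the series gains its first step beyond the scatter, and the group on this oxygen now clearly bears on the number. The change falls on the isopropoxycarbonyl group, which stays untouched in a 1.0-fold lower number from compound 1 to compound 2 (0.02 log units; within the scatter) and so was never tested by that level step; isopropoxy to cyclopropylmethoxy is the first change shown at this group alone, and it gives a weaker inhibitor. The data at hand offer no measurement that accounts for this rise.

On these data alone, whether the three-membered ring or the added carbon goes with the higher number stays open, and an n-butyl or isobutyl group on the same oxygen would separate the two. Equally open, as far as these compounds go, is how a carboxylic acid in place of the isopropoxycarbonyl group would read.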